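The source may report more compounds than this note shows. Statements on the series, on what has been measured and on what is new or still open speak of the compounds shown alone.

Measured compounds:
compound 1 `O=Cc1c(-c2ccc(F)cc2)nc2sc(Cc3ccc(Cl)cc3)nn12` — 20000 nM in a functional assay on L1210 cells (Mus musculus) for cytotoxicity, with a stated time of 48 h; a higher number here means a weaker inhibitor, a lower number a stronger inhibitor
compound 2 `Cc1ccc(-c2nc3sc(Cc4ccc(Cl)cc4)nn3c2C=O)cc1` — 23000 nM in this assay

Among the measured compounds shown here, compound 2 is one of only two compounds measured, and its number and that of compound 1 fall within the scatter of each other, as the step of a 1.2-fold higher number from compound 1 to compound 2 (0.06 log units; within the scatter) shows; neither stands apart. Compound 3 `Cc1ccc(-c2nc3sc(Cc4ccc(Cl)cc4)nn3c2SC#N)cc1` differs from compound 2 by cyanosulfanyl in place of formyl on an aromatic carbon. For the measured compounds named here, the single measured step, a 1.2-fold higher number from compound 1 to compound 2 (0.06 log units; within the scatter), touches a different part of the molecule and is itself within the scatter, so it offers no guide to this change. In this assay compound 3 is expected to show a 1.2-fold lower number from compound 2 to compound 3 (0.06 log units; within the scatter). The estimate for compound 3 is 20000 nM, with a range from 5000 nM to 80000 nM.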

Compound 3, half-maximal inhibitory concentration: 32000 nM
Beside the measured number, compound 3's estimate is 1.6-fold (0.20 log units) below it, within the range that was stated.
By their numbers in this assay, from the lowest: compounds 1, 2 and 3 (each within the scatter of the next).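

At this position, on the aromatic carbon of the five-membered ring, cyanosulfanyl in place of formyl in this assay gives a 1.4-fold higher number from compound 2 to compound 3 (0.14 log units; within the scatter) and so leaves the number within the scatter. The group at this position can therefore be exchanged for one with a triple bond and a sulfur atom without a change that this assay can distinguish, something the earlier step, made elsewhere on the molecule, could not show. No available evidence bears on this result. Going by these compounds, whether an amine, a carboxylic acid or a longer chain at this position would give a number beyond the scatter remains open.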